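From ethyl to formyl on the shared core

The source may hold more compounds than are shown below. What is called first, only, known or untested is meant among the compounds shown, and "the series" means these compounds.

Three compounds share one core: compound 1 (`Nc1c(F)c(=O)[nH]c(=O)n1[C@@H]1O[C@H](CO)[C@@H](O)[C@H]1O`), compound 2 (`CCc1c(F)c(=O)[nH]c(=O)n1[C@@H]1O[C@H](CO)[C@@H](O)[C@H]1O`) and compound 3 (`O=Cc1c(F)c(=O)[nH]c(=O)n1[C@@H]1O[C@H](CO)[C@@H](O)[C@H]1O`). Within the data shown here, in a functional assay on OCI-AML2 cells (Homo sapiens) for antiproliferative activity, read by WST assay, with a stated time of 3 days (a lower number here means a stronger inhibitor, a higher number a weaker inhibitor), compound 1 gives 900 nM and this is the only number available so far. For compound 2 the record reads "not determined" (no result reported) so this compound has no place on the scale. The structural change runs formyl in place of ethyl on an aromatic carbon and puts formyl in place of ethyl on an aromatic carbon, ortho to a fluoro group. With no number for compound 2, the size of this step in this assay cannot be read from the data. Set against compound 1 at 900 nM as the sole anchor, compound 3 is expected to shift slightly toward weaker inhibition, scarcely beyond the scatter. The value of compound 3 is estimated at 2000 nM with an expected range from 300 nM to 10000 nM for now.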

Compound 3, half-maximal inhibitory concentration: 700 nM
Compound 3: the middle estimate sits 2.9-fold (0.46 log units) above what was measured; the range from low to high includes it.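

In this assay the change from amino to formyl on this aromatic carbon, ortho to a fluoro group, comes to a 1.3-fold lower number from compound 1 to compound 3 (0.11 log units; within the scatter) and so gives no separation between the two groups on this read-out. Among these compounds, this is the first readable comparison at the position, and it shows that formyl can stand in place of amino with the antiproliferative value remaining within the scatter. The data offer no measured explanation for this result.

As far as these compounds go, the step from compound 2 to compound 3 cannot be read, so the effect of ethyl at this position remains unknown. From the compounds shown here alone, it also remains open whether a carboxylic acid, a hydroxymethyl group or a longer chain on the same carbon would give a value in the same range.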